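From a triazole diol to a methylpiperazine chain

The source may report more compounds than this note shows. Statements on the series, on what has been measured and on what is new or still open speak of the compounds shown alone.

In a functional assay on MDA-MB-231 cells (Homo sapiens) for cytotoxicity, read by MTT assay, with a stated time of 72 h (on this read-out lower numbers stand for stronger inhibition and higher numbers for weaker inhibition), compound 1 (`CN1CCN(CCCn2c3c(c4ccccc42)C(=O)c2c[n+]([O-])c4ccccc4c2C3=O)CC1`) gives 390 nM. Compound 2 (`O=C1c2c[n+]([O-])c3ccccc3c2C(=O)c2c1c1ccccc1n2Cc1cn(C[C@@H](O)CO)nn1`) gives 670 nM, so these two compounds lie within the usual scatter of each other. Compound 3 (`CN1CCN(CCCCCn2c3c(c4ccccc42)C(=O)c2c[n+]([O-])c4ccccc4c2C3=O)CC1`) keeps the shared core and differs from compound 2 in one place: 4-(4-methylpiperazin-1-yl)butyl in place of 1-(2,3-dihydroxypropyl)-1H-1,2,3-triazol-4-yl on a saturated chain carbon bound to an aromatic nitrogen. Going by the values given here, the only measured step bearing on this change is the exchange in the opposite sense, a 1.7-fold higher number from compound 1 to compound 2 (0.24 log units; within the scatter), in which 1-(2,3-dihydroxypropyl)-1H-1,2,3-triazol-4-yl replaced 2-(4-methylpiperazin-1-yl)ethyl. Among the compounds with values here, compound 3 carries a longer methylpiperazine chain than compound 1, and no measurement yet shows what chain length does. No step beyond the scatter is therefore expected in this assay. The step expected is a 1.7-fold lower number from compound 2 to compound 3 (0.22 log units; within the scatter). Compound 3 is estimated at 400 nM, with an expected range from 150 nM to 1100 nM.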

Compound 3, half-maximal inhibitory concentration: 2270 nM
Estimate against measurement, compound 3: 5.7-fold (0.75 log units) below, and the stated range ends below it.
By their numbers in this assay, from the lowest: compounds 1 and 2 (each within the scatter of the next); then compound 3.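

In this assay, going by these compounds alone, the 5-(4-methylpiperazin-1-yl)pentyl chain gives the first steps beyond the scatter at this position, both from the shorter methylpiperazine chain (a 5.8-fold higher number from compound 1 to compound 3 (0.76 log units; beyond the scatter)) and from the triazole diol (a 3.4-fold higher number from compound 2 to compound 3 (0.53 log units; beyond the scatter)). Chain length on the aromatic nitrogen therefore counts here, and the closeness of compound 1 and compound 2 does not carry over to every chain that ends in methylpiperazine. Nothing at hand accounts for this rise in the number.

With only two lengths of the methylpiperazine chain shown, it remains open whether the number climbs gradually or abruptly between them. As far as these compounds go, it also remains open whether a morpholine or a dimethylamine at the end of the longer chain would behave as the methylpiperazine does.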